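Growing the Side Chain Past Compound 2

The compounds below may be only part of what the source reports. "The series", "measured", "known", "first", "only" and "open" are said of these compounds alone.

Measured in a functional assay on A9L-m1 cells with A9 (Mus musculus) as the target (a lower number here means a smaller maximal response, a higher number a larger maximal response), so far:
compound 1 `CCOc1nccnc1C1CN2CCC1CC2`: 1%
compound 2 `CCCCOc1nccnc1C1CN2CCC1CC2`: 15%

For the measured compounds named here, compound 2 stands at the higher of the two numbers; the only other measured compound, compound 1, lies a number 14 percentage points higher from compound 1 to compound 2 (beyond the scatter). Compound 3 `CCCCCCCOc1nccnc1C1CN2CCC1CC2` differs from compound 2 in one place: propyl in place of hydrogen on a saturated chain carbon, four bonds along the chain from an oxygen on an aromatic ring. Going by the values given here, the one measured step that bears on this change is the earlier chain growth, which gave a number 14 percentage points higher from compound 1 to compound 2 (beyond the scatter). Another, longer extension of the same chain is therefore expected to raise the maximum again, by about a number 15 percentage points higher from compound 2 to compound 3 (beyond the scatter). Compound 3 is estimated at 30%, between 5% and 60%.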

Compound 3, largest response reached (reported as maximum), in percent of the reference or control that the assay uses: 35%
Compound 3: the middle estimate sits 5 percentage points below what was measured; low and high end bracket the measured number.
By their numbers in this assay, from the lowest: compound 1; then compound 2; then compound 3.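

In this assay, the rise did not stop with the first chain growth: propyl in place of hydrogen, on a saturated chain carbon four bonds along the chain from the oxygen, still gives (a number 20 percentage points higher from compound 2 to compound 3 (beyond the scatter)). Over the whole extension, pentyl in place of hydrogen two bonds along the chain gives (a number 34 percentage points higher from compound 1 to compound 3 (beyond the scatter)), so across these three compounds the longer chain goes with the larger maximum. No measurement at hand explains why the response climbs in this way.

Going by these compounds, whether a still longer chain keeps raising the maximum remains open. So does whether a chain ending in an amine or a carboxylic acid would behave like these plain carbon chains.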